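Taking the Fluorine off Compound 3

This account rests on a few compounds, and the source may have more. Where it says the series, first, only, none or still open, it means among the compounds named here.

Of the compounds shown here, three sharing one core have been measured in a functional assay on DLD-1 cells (Homo sapiens) for cytotoxicity, read by colorimetric assay and MTT assay, with a stated time of 3 days, tested at 20 uM; on this read-out higher numbers stand for a weaker effect at the one concentration tested and lower numbers for a stronger effect. Compound 1 `O=C1COc2ccc(-c3[nH]c(-c4ccc(C(F)(F)F)cc4)nc3-c3ccccc3)cc2N1` gives 12.1%, and compound 2 `O=C1COc2ccc(-c3[nH]c(-c4ccc(F)cc4)nc3-c3ccccc3)cc2N1` gives 29.5%. Among the compounds with values here, the step of a number 17.4 percentage points higher from compound 1 to compound 2 (beyond the scatter) is the only single change measured so far. Compound 3 `O=C1COc2ccc(-c3nn(-c4ccc(F)cc4)cc3-c3ccccc3)cc2N1` gives 45.2%, the highest of the three numbers and beyond the scatter from both others. Compound 4 `O=C1COc2ccc(-c3nn(-c4ccccc4)cc3-c3ccccc3)cc2N1` differs from compound 3 by hydrogen in place of fluoro on an aromatic carbon. Within the data shown here, no measured step swaps a fluoro for a hydrogen, and the trifluoromethyl-to-fluoro step concerns a different group, so it offers only weak guidance. A small shift is expected, a number 2.8 percentage points higher from compound 3 to compound 4 (within the scatter), within the scatter. Compound 4 is therefore estimated at 48%, with a range from 30% to 66%.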

Compound 4, a percentage reported as activity, at one concentration (the size of the read-out at that concentration, not a potency): 47.7%
The estimate for compound 4 lay 0.3 percentage points above the measured number, within the range that was stated.
By their numbers in this assay, from the lowest: compound 1; then compound 2; then compounds 3 and 4 (each within the scatter of the next).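

In this assay, hydrogen in place of fluoro on this aromatic carbon gives a number 2.5 percentage points higher from compound 3 to compound 4 (within the scatter), the first such swap shown. On this core, then, going from 4-fluorophenyl to phenyl produces no readable change, so the fluoro is not needed to keep this read-out where it stands. Nothing available explains this result.

Still open, on these data alone, is whether an amine or a carboxylic acid on that same carbon would shift the number. It is also unknown whether the same swap on the core of compound 2 would behave alike.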